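A few compounds are considered here, and "the series" means these few. Any claim that something is new, unique, unknown or untested is made for them only; others in the source may bear on it.

The series shares one core, and it is read in a functional assay for antagonist activity at integrin alpha-5/beta-1 (Homo sapiens), read by ELISA; on this read-out lower numbers stand for stronger inhibition and higher numbers for weaker inhibition. Compound 1, with structure `COC(=O)N1C[C@@]2(CC(C(=O)NC[C@H](NS(=O)(=O)c3c(C)cc(C)cc3C)C(=O)O)=NO2)C[C@H]1CNc1nc2ccccc2[nH]1`, gives 1.4 nM in this assay. Compound 2, with structure `CCCCOC(=O)N1C[C@@]2(CC(C(=O)NC[C@H](NS(=O)(=O)c3c(C)cc(C)cc3C)C(=O)O)=NO2)C[C@H]1CNc1ncc[nH]1`, gives 14 nM, the higher of the two numbers recorded, and its gap to compound 1 lies beyond the usual scatter. Compound 1 and compound 2 differ in more than one place, so no single change can be credited with that gap from their two values alone.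

Compound 3, with structure `CCCCOC(=O)N1C[C@@]2(CC(C(=O)NC[C@H](NS(=O)(=O)c3c(C)cc(C)cc3C)C(=O)O)=NO2)C[C@H]1CNc1nc2ccccc2[nH]1`, has not yet been measured. It differs from compound 2 at one site: 1H-benzimidazol-2-yl in place of 1H-imidazol-2-yl on an amine nitrogen. The group that enters is the same 1H-benzimidazol-2-yl group that compound 1 carries. Because compound 1 reaches 1.4 nM while compound 2 stands at 14 nM, and part of that gap may travel with this group, a step toward stronger inhibition is expected, though of modest size, since the remainder of the gap between compound 1 and compound 2 is left unexplained. The expected step is a 3.5-fold lower number from compound 2 to compound 3 (0.54 log units; beyond the scatter). Compound 3 is therefore estimated at 4 nM in this assay, within a range from 1.5 nM to 12 nM.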

Compound 3, half-maximal inhibitory concentration: 0.39 nM
Compound 3: middle estimate off by 10-fold (1.01 log units), on the high side; measured number below the stated range.
By their numbers in this assay, from the lowest: compound 3; then compound 1; then compound 2.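

With the rest of the structure unchanged, 1H-benzimidazol-2-yl in place of 1H-imidazol-2-yl on the amine nitrogen gives in this assay a 36-fold lower number from compound 2 to compound 3 (1.56 log units; beyond the scatter) and shows that this one site, bearing a saturated chain carbon as its other neighbour, can by itself move the read-out by a large margin. The same compound also lets the second site be read alone: propyl in place of hydrogen on a saturated chain carbon bound to an oxygen next to a carbonyl group gives a 3.6-fold lower number from compound 1 to compound 3 (0.56 log units; beyond the scatter) and shows that, with 1H-benzimidazol-2-yl in place, the longer chain goes with stronger inhibition rather than weaker. Both steps end at compound 3 and run in the same direction, and the step at the amine nitrogen is the large one while the step at the chain is modest.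

As far as these compounds go, it remains open whether the added six-membered aromatic ring of carbon only must be fused as it is in 1H-benzimidazol-2-yl, or whether a phenyl or 2-pyridyl group on the same amine nitrogen, or a hexyl chain in place of the butyl chain, would carry the read-out further. Nothing among the data shown explains why either step has the size it has.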